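This account rests on a few compounds, and the source may have more. Where it says the series, first, only, none or still open, it means among the compounds named here.

Compound 1 `Nc1cccc(/C=C2\SC(=O)N(Cc3cccc(Cl)c3)C2=O)c1` gives 195000 nM in a functional assay on CCRF-CEM cells (Homo sapiens) for cytotoxicity, read by cell counting, with a stated time of 3 days (a lower number here means a stronger inhibitor, a higher number a weaker inhibitor), and compound 2 `Nc1cccc(/C=C2\SC(=O)N(Cc3cccc(F)c3)C2=O)c1` gives 250000 nM in this assay. The change from compound 1 to compound 2, (fluoro in place of chloro on an aromatic carbon), produced a 1.3-fold higher number from compound 1 to compound 2 (0.11 log units; within the scatter). Compound 3 `C=C(Br)C(=O)Nc1ccc(/C=C2\SC(=O)N(Cc3cccc(Cl)c3)C2=O)cc1` gives 3700 nM in this assay, the lowest of the three numbers; how the core of compound 3 differs from the core of compound 1 is not broken down here. Compound 4 `C=C(Br)C(=O)Nc1ccc(/C=C2\SC(=O)N(Cc3cccc(F)c3)C2=O)cc1` has not been measured in this assay. It differs from compound 3 by fluoro in place of chloro on an aromatic carbon, the same change as that from compound 1 to compound 2, at the same kind of place. Because the earlier step was a 1.3-fold higher number from compound 1 to compound 2 (0.11 log units; within the scatter), the step of a 1.2-fold higher number from compound 3 to compound 4 (0.09 log units; within the scatter) is expected to be small. Compound 4 is therefore estimated at 4500 nM in this assay, with a likely range from 2000 nM to 10000 nM.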

Compound 4, half-maximal inhibitory concentration: 3200 nM
The estimate for compound 4 lay 1.4-fold (0.15 log units) above the measured number, and the stated range covers the measured number.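

Replacing 3-chlorobenzyl with 3-fluorobenzyl leaves this assay within the scatter, a 1.2-fold lower number from compound 3 to compound 4 (0.06 log units; within the scatter). The change carries across the two cores shown with no detectable difference: the same change on two cores in this assay, a 1.3-fold higher number (0.11 log units; within the scatter) from compound 1 to compound 2 and a 1.2-fold lower number (0.06 log units; within the scatter) from compound 3 to compound 4, 1.5-fold (0.17 log units) apart, within the scatter of two such steps

This supports treating chloro and fluoro at this place as interchangeable on these two cores in this one cytotoxicity read-out, but it gives no order between the two halogens and does not extend to other cores or other assays.

Still open, as far as these compounds go, is whether a group that is not a halogen, such as methoxy, an amine or a carboxylic acid, would give similarly small steps at this place. Also open, from the compounds shown here alone, is whether any such step would match on both cores.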